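A few compounds are considered here, and "the series" means these few. Any claim that something is new, unique, unknown or untested is made for them only; others in the source may bear on it.

Working notes on the series. Three compounds share one core and differ only in the halogen on an aromatic carbon. Compound 1 `CCOC(=O)C1=C(C)N(c2ccc(F)cc2)C=CC1c1ccccc1` gives -35.8% in a functional assay for inhibition, using microsomes, tested at 200 ug/mL; a lower number here means a stronger effect, a higher number a weaker effect of the compound at the concentration tested. Compound 2 `CCOC(=O)C1=C(C)N(c2ccc(Cl)cc2)C=CC1c1ccccc1` gives -34.4% in this assay, and compound 3 `CCOC(=O)C1=C(C)N(c2ccc(Br)cc2)C=CC1c1ccccc1` gives -32.1%. The three steps among them are small: a number 1.4 percentage points higher from compound 1 to compound 2 (within the scatter), a number 3.7 percentage points higher from compound 1 to compound 3 (within the scatter) and a number 2.3 percentage points higher from compound 2 to compound 3 (within the scatter). On the numbers shown, compound 2 sits between compound 1 and compound 3, and both of its steps to them stay within the scatter, so the three halogens cannot be told apart in this assay.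

Compound 4 `CC1=C(C(=O)OC(C)(C)C)C(c2ccccc2)C=CN1c1ccc(Cl)cc1` has not yet been measured. It differs from compound 2 by tert-butyl in place of ethyl on an oxygen next to a carbonyl group. Among the compounds with values here, no measured step touches this part of the molecule; all three measured steps exchange one halogen for another on an aromatic carbon, and none of them left the scatter. The series therefore gives no direct guide for the ester change, and the only observation available is that every change tried so far produced no step beyond the scatter. On that basis the step from compound 2 to compound 4 is expected to be a number 0.4 percentage points higher from compound 2 to compound 4 (within the scatter), with a wide uncertainty. Compound 4 is estimated at -34% in this assay, within a range from -55% to -12%.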

Compound 4, a percentage reported as activity, at one concentration (the size of the read-out at that concentration, not a potency): -26.6%
Beside the measured number, compound 4's estimate is 7.4 percentage points below it; measured number inside the range.
By their numbers in this assay, from the lowest: compounds 1, 2, 3 and 4 (each within the scatter of the next).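

The replacement of ethyl by tert-butyl on an oxygen next to a carbonyl group gives the first measured step away from the halogen, and in this assay it reads (a number 7.8 percentage points higher from compound 2 to compound 4 (within the scatter)). This step is larger than the three halogen steps but does not leave the scatter, so compound 4 cannot be told apart from compound 2, and the bulkier-named tert-butoxycarbonyl group shows no clear difference from ethoxycarbonyl at the single concentration tested. Nothing at hand bears on the reason for this result.

On these data alone, it remains open whether a group of another kind in this place, such as a carboxylic acid, an amide or a longer chain on the oxygen, would give a step beyond the scatter in this assay or whether every change here stays within it. Within the data shown here, it is also open whether tert-butyl in place of ethyl reads the same with fluoro or bromo on the aromatic carbon, since this change is seen only with chloro.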